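Chain Extension on an Arylsulfonate Urea Series

The compounds below may be only part of what the source reports. "The series", "measured", "known", "first", "only" and "open" are said of these compounds alone.

Three measured compounds share one core and differ only in the group that caps an amide-type nitrogen. Compound 1 `CC(=O)Nc1ccc(S(=O)(=O)Oc2ccccc2C(C)C)cc1` is the smallest; in a functional assay on MCF7 cells (Homo sapiens) for antiproliferative activity, read by sulforhodamine B assay, with a stated time of 48 h (a higher number here means a weaker inhibitor, a lower number a stronger inhibitor), compound 1 gives 16000 nM. Compound 2 `CCCC(=O)Nc1ccc(S(=O)(=O)Oc2ccccc2C(C)C)cc1` carries a longer chain, the change being (ethyl in place of hydrogen on a saturated chain carbon bound to a carbonyl carbon), and in this assay compound 2 gives 6600 nM; the step is a 2.4-fold lower number from compound 1 to compound 2 (0.38 log units; beyond the scatter). Compound 3 `CCCNC(=O)Nc1ccc(S(=O)(=O)Oc2ccccc2C(C)C)cc1` differs from compound 1 by propylamino in place of methyl on a carbonyl carbon, and in this assay compound 3 gives 2700 nM, the lowest number of the three, with a 5.9-fold lower number from compound 1 to compound 3 (0.77 log units; beyond the scatter) and a 2.4-fold lower number from compound 2 to compound 3 (0.39 log units; beyond the scatter).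

Compound 4 `CCCCCNC(=O)Nc1ccc(S(=O)(=O)Oc2ccccc2C(C)C)cc1` is not yet measured. It differs from compound 3 by ethyl in place of hydrogen on a saturated chain carbon, three bonds along the chain from an amide-type nitrogen. Within the data shown here, this is the same kind of change as the one from compound 1 to compound 2, but not the same: there the place is on a saturated chain carbon bound to a carbonyl carbon, here it is on a saturated chain carbon, three bonds along the chain from an amide-type nitrogen, and the two cores differ by propylamino in place of methyl on a carbonyl carbon.

Among the measured compounds shown here, for compound 4 in this assay a step of about a 1.8-fold lower number from compound 3 to compound 4 (0.26 log units; within the scatter) is expected, resting on the single earlier example of this kind of change, where the step was a 2.4-fold lower number from compound 1 to compound 2 (0.38 log units; beyond the scatter); with one example and a different core, the expectation is held loosely. Compound 4 is estimated at 1500 nM, most likely between 600 nM and 4000 nM.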

Compound 4, half-maximal inhibitory concentration: 4000 nM
Compound 4: the middle estimate sits 2.7-fold (0.43 log units) below what was measured; measured number inside the range.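

Adding ethyl to a chain does not behave the same way on these two cores in this assay, and the two steps differ: the same change on two cores in this assay, a 2.4-fold lower number (0.38 log units; beyond the scatter) from compound 1 to compound 2 and a 1.5-fold higher number (0.17 log units; within the scatter) from compound 3 to compound 4, 3.6-fold (0.56 log units) apart, beyond the scatter of two such steps

On the core of compound 3, the new step, a 1.5-fold higher number from compound 3 to compound 4 (0.17 log units; within the scatter), is too small to separate the propylamino and pentylamino groups, and a 1.7-fold lower number from compound 2 to compound 4 (0.22 log units; within the scatter) likewise leaves the butyramide-type compound and the pentylamino urea-type compound unseparated, while a 4.0-fold lower number from compound 1 to compound 4 (0.60 log units; beyond the scatter) remains a real difference from the smallest compound of the set. So a benefit seen for this change on one core cannot be assumed to carry over to another core in this series. Among these compounds, this does not show that the longer chain harms activity on the core of compound 3, and with only one pair on each core it gives no general rule and no explanation for the difference.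

The compounds shown leave open what a butylamino group or a hexylamino group would give on the core of compound 3, and so whether the values follow any trend with chain length. They also leave open what a chain ending in a hydroxyl group or an amine would give.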